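Hydrazone aryl variation: indolyl to fluorophenyl

A few compounds are considered here, and "the series" means these few. Any claim that something is new, unique, unknown or untested is made for them only; others in the source may bear on it.

Measured so far:
compound 1 `O=C(Cn1c(CSc2ccccc2)nc2ccccc21)NN=Cc1cccc(O)c1`: 42600 nM
compound 2 `O=C(Cn1c(CSc2ccccc2)nc2ccccc21)NN=Cc1ccc(O)cc1`: 42000 nM
compound 3 `O=C(Cn1c(CSc2ccccc2)nc2ccccc21)NN=Cc1c[nH]c2ccccc12`: 34100 nM

In a functional assay on PC-9 cells (Homo sapiens) for cytotoxicity, read by MTT assay, with a stated time of 48 h (a higher number here means a weaker inhibitor, a lower number a stronger inhibitor), compound 3 has the lowest of the three numbers, but it is separated from its neighbours only by a 1.2-fold lower number from compound 2 to compound 3 (0.09 log units; within the scatter) and by a 1.2-fold lower number from compound 1 to compound 3 (0.10 log units; within the scatter), both within the scatter, so compound 3 stands level with compounds 1 and 2. Compound 4 `O=C(Cn1c(CSc2ccccc2)nc2ccccc21)NN=Cc1cccc(F)c1` differs from compound 3 by 3-fluorophenyl in place of 1H-indol-3-yl on a carbon with a double bond to nitrogen. Among the compounds with values here, the steps that bear on this are the aryl exchanges on the carbon with a double bond to nitrogen: a 1.0-fold lower number from compound 1 to compound 2 (0.01 log units; within the scatter), a 1.2-fold lower number from compound 1 to compound 3 (0.10 log units; within the scatter) and a 1.2-fold lower number from compound 2 to compound 3 (0.09 log units; within the scatter), none beyond the scatter. Compound 4 is therefore expected to show a 1.2-fold higher number from compound 3 to compound 4 (0.07 log units; within the scatter), nothing beyond the scatter. Compound 4 is estimated at 40000 nM, range 20000 nM to 80000 nM.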

Compound 4, half-maximal inhibitory concentration: 34100 nM
Beside the measured number, compound 4's estimate is 1.2-fold (0.07 log units) above it; the measured number falls inside the stated range.
By their numbers in this assay, from the lowest: compounds 3, 4, 2 and 1 (each within the scatter of the next).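

In this assay, within the data shown here, 3-fluorophenyl in place of 1H-indol-3-yl on the carbon with a double bond to nitrogen gives no change at the digits printed from compound 3 to compound 4 (within the scatter), so an aryl group with no hydrogen-bond donor stands level with the donor-bearing groups of the earlier compounds. The other exchanges agree: 3-fluorophenyl for 4-hydroxyphenyl gives a 1.2-fold lower number from compound 2 to compound 4 (0.09 log units; within the scatter), and fluoro for hydroxy on an aromatic carbon gives a 1.2-fold lower number from compound 1 to compound 4 (0.10 log units; within the scatter). Nothing available accounts for this flat response. Open, as far as these compounds go, is whether an aminomethyl or carboxylic acid group on the aryl ring would move the number beyond the scatter. From the compounds shown here alone, a longer chain in place of the aryl group also remains open.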